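A Single Enantiomer Drawn Out of Compound 3

This account rests on a few compounds, and the source may have more. Where it says the series, first, only, none or still open, it means among the compounds named here.

Compound 3 `N#C/C(=C\c1cccc(Br)n1)C(=O)NC(c1ccccc1)C1CC1` gives 1100 nM in a functional assay on MM1 cells (Homo sapiens) for antiproliferative activity, read by MTT assay, with a stated time of 72 h (a lower number here means a stronger inhibitor, a higher number a weaker inhibitor), the lowest of the three numbers measured: compound 1 `N#C/C(=C\c1cccc(Br)n1)C(=O)N[C@@H](CO)c1ccccc1` gives 2800 nM and compound 2 `COC(=O)C[C@H](NC(=O)/C(C#N)=C/c1cccc(Br)n1)c1ccccc1` gives 3100 nM, both beyond the scatter above compound 3. Among the measured compounds shown here, the one single-point step among them, a 1.1-fold higher number from compound 1 to compound 2 (0.04 log units; within the scatter), concerns a chain substituent rather than a stereocentre, so no measured step bears on the change to compound 4 `N#C/C(=C\c1cccc(Br)n1)C(=O)N[C@H](c1ccccc1)C1CC1`, where (the two compounds have the same atoms and bonds; at least one stereo element is drawn with a configuration in one of them and without one in the other: 1 of 2 stereo elements differ; a stereocentre at a saturated chain carbon is drawn without a configuration in compound 3 and S in compound 4). Compound 3 is drawn without a configuration at that centre and compound 4 with one; the number could fall if compound 4 is the more active form, or rise if the less active. With nothing to favour either, the expected step is a 1.4-fold lower number from compound 3 to compound 4 (0.14 log units; within the scatter), and compound 4 is estimated at 800 nM with a range from 300 nM to 2500 nM.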

Compound 4, half-maximal inhibitory concentration: 1400 nM
Estimate against measurement, compound 4: 1.8-fold (0.24 log units) below; measured number inside the range.
By their numbers in this assay, from the lowest: compounds 3, 4, 1 and 2 (each within the scatter of the next, the first and the last beyond it).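

In this assay, the defined S centre brings no change beyond the scatter (a 1.3-fold higher number from compound 3 to compound 4 (0.10 log units; within the scatter)), and this sets one configuration against an undefined drawing rather than against its opposite, because of one fact: the fact that one of compounds 3 and 4 is drawn with a defined configuration and the other without, at the place where they differ. At that same carbon, cyclopropyl in place of (methoxycarbonyl)methyl gives a modest step beyond the scatter (a 2.2-fold lower number from compound 2 to compound 4 (0.35 log units; beyond the scatter)), while cyclopropyl in place of hydroxymethyl stays within it (a 2.0-fold lower number from compound 1 to compound 4 (0.30 log units; within the scatter)). Still open, from the compounds shown here alone, is how the R configuration at this carbon would read, and whether an amine or a longer chain in place of cyclopropyl would keep the number of compound 4.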